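From Carboxy to Ethoxycarbonyl on a Shared Core

The source may report more compounds than this note shows. Statements on the series, on what has been measured and on what is new or still open speak of the compounds shown alone.

- Compound 1 `NC[C@H]1OC(n2cc(F)c(=O)[nH]c2=O)[C@H](O)[C@@H]1O`: 38 uM
- Compound 2 `O=C(O)[C@H]1OC(n2cc(F)c(=O)[nH]c2=O)[C@H](O)[C@@H]1O`: > 1000 uM (a limit)

In a functional assay on L1210 cells (Mus musculus) for cytotoxicity (on this read-out lower numbers stand for stronger inhibition and higher numbers for weaker inhibition), compound 2 gives > 1000 uM, which is a limit of the assay and not a number. Compound 3 `CCOC(=O)[C@H]1OC(n2cc(F)c(=O)[nH]c2=O)[C@H](O)[C@@H]1O` carries ethyl in place of hydrogen on an oxygen next to a carbonyl group, so carboxy becomes ethoxycarbonyl: ethyl in place of hydrogen on an oxygen next to a carbonyl group.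

Within the data shown here, only one measured step bears on this change. The large step of an at least 26-fold higher number from compound 1 to compound 2 (1.42 log units; beyond the scatter) introduces the same carboxy group that is altered here, which suggests that this part of the molecule matters. It does not test ethoxycarbonyl, so the size of the new step remains uncertain. A move toward lower numbers in this assay is expected, and the expected step is an at least 5.0-fold lower number from compound 2 to compound 3 (0.69 log units; beyond the scatter). For compound 3 the estimated value is 200 uM, with an expected range of 40 uM to 1000 uM.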

Compound 3, concentration for 50% inhibition: > 1000 uM
Compound 3: no number, only a limit (the forecaster's own chance of this, stated with the estimate: 35%); middle value at least 5.0-fold (0.69 log units) from the limit.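

In this assay compound 3 gives > 1000 uM, which is a limit of the assay and not a number. Ethoxycarbonyl in place of aminomethyl gives an at least 26-fold higher number from compound 1 to compound 3 (1.42 log units; beyond the scatter), so putting ethyl on the carboxy group does not restore the lower number seen for compound 1. The step from compound 2 to compound 3 cannot be read, because both compounds stop at the same limit: the limit of > 1000 uM in this assay, at which 2 of the 3 values shown sit.

On these data alone, whether ethyl in place of hydrogen changes the read-out at all stays open, as does where the true values of compound 2 and compound 3 lie. Also open, as far as these compounds go, is how a carboxamide or a hydroxymethyl group on the same saturated ring carbon would read, and whether either would come close to compound 1 or stop at the limit.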